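Swapping an Anilino Group for a Methoxyazetidine

The source may report more compounds than this note shows. Statements on the series, on what has been measured and on what is new or still open speak of the compounds shown alone.

Measured so far:
compound 1 `COc1ccc2c(c1)NC(=O)CN2c1nc(Nc2cccc(C#N)c2)nc2ccccc12`: 61.5 nM
compound 2 `COc1ccc2c(c1)NC(=O)CN2c1nc(COC(C)=O)nc2ccccc12`: 5.05 nM

In a functional assay on KB cells (Homo sapiens) for inhibition, read by sulforhodamine B assay, with a stated time of 48 h (on this read-out higher numbers stand for weaker inhibition of growth and lower numbers for stronger inhibition of growth), compound 1 gives the higher of the two numbers, with compound 2 standing a 12-fold lower number from compound 1 to compound 2 (1.09 log units; beyond the scatter). Compound 3 `COc1ccc2c(c1)NC(=O)CN2c1nc(N2CC(OC)C2)nc2ccccc12` is not yet measured. It differs from compound 1 by 3-methoxyazetidin-1-yl in place of (3-cyanophenyl)amino on an aromatic carbon. Within the data shown here, the only measured step replaces the same group at the same place, but with a different group, so it bears on this change only loosely: it shows that removing the (3-cyanophenyl)amino group can give a large drop, yet it does not show what 3-methoxyazetidin-1-yl will do. A lower number is expected for compound 3, with wide uncertainty. Compound 3 is estimated at 20 nM, within 5 nM to 100 nM, which is expected as a 3.1-fold lower number from compound 1 to compound 3 (0.49 log units; beyond the scatter).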

Compound 3, concentration for 50% growth inhibition: 8.26 nM
Compound 3: middle estimate off by 2.4-fold (0.38 log units), on the high side, within the range that was stated.
By their numbers in this assay, from the lowest: compounds 2 and 3 (each within the scatter of the next); then compound 1.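

In this assay replacing the (3-cyanophenyl)amino group with 3-methoxyazetidin-1-yl also gives a lower number (a 7.4-fold lower number from compound 1 to compound 3 (0.87 log units; beyond the scatter)), so the earlier drop is not unique to acetoxymethyl. The two replacements cannot be separated (a 1.6-fold higher number from compound 2 to compound 3 (0.21 log units; within the scatter)), although one brings a four-membered ring and the other has no ring. Nothing available explains these results. On these data alone, whether the methoxy group matters remains open, since a plain azetidine would be needed to test it. As far as these compounds go, how a simple amine or a longer chain at this position would compare also remains open.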